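A few compounds are considered here, and "the series" means these few. Any claim that something is new, unique, unknown or untested is made for them only; others in the source may bear on it.

Measured compounds:
compound 1, `CC(=O)Nc1nc2ccc(NC(=O)c3c(Cl)cccc3Cl)cc2s1`, 0.6 ug/mL in a functional assay on WI-38 VA13 cells (Homo sapiens) for cytotoxicity; on this read-out higher numbers stand for an effect only at larger amounts of compound and lower numbers for an effect already at smaller amounts
compound 2, `CCCC(=O)Nc1nc2ccc(NC(=O)c3c(Cl)cccc3Cl)cc2s1`, 0.01 ug/mL in this assay
compound 3, `CCCCNC(=O)Nc1nc2ccc(NC(=O)c3c(Cl)cccc3Cl)cc2s1`, 0.028 ug/mL in this assay

The three measured compounds share the same core and differ only in the group on the amide-type nitrogen. Going from compound 1 to compound 2 the change is ethyl in place of hydrogen on a saturated chain carbon bound to a carbonyl carbon, and it brings a 60-fold lower number from compound 1 to compound 2 (1.78 log units; beyond the scatter). Going from compound 1 to compound 3 the change is butylamino in place of methyl on a carbonyl carbon, which brings a 21-fold lower number from compound 1 to compound 3 (1.33 log units; beyond the scatter). Between compound 2 and compound 3 the gap is smaller: a 2.8-fold higher number from compound 2 to compound 3 (0.45 log units; beyond the scatter).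

Compound 4, `CCCCCCNC(=O)Nc1nc2ccc(NC(=O)c3c(Cl)cccc3Cl)cc2s1`, has not yet been measured. It differs from compound 3 by ethyl in place of hydrogen on a saturated chain carbon, four bonds along the chain from an amide-type nitrogen. Within the data shown here, this is the same kind of change as the one from compound 1 to compound 2, where the ethyl entered on a saturated chain carbon bound to a carbonyl carbon, whereas here it enters on a saturated chain carbon four bonds along the chain from an amide-type nitrogen. The cores of compound 1 and compound 3 differ by butylamino in place of methyl on a carbonyl carbon.

Because a 60-fold lower number from compound 1 to compound 2 (1.78 log units; beyond the scatter) shows that the earlier chain extension gave a large step, compound 4 is expected to give a lower number than compound 3, but the place of the change lies further out, so a smaller step is expected: a 1.9-fold lower number from compound 3 to compound 4 (0.27 log units; within the scatter). In this assay compound 4 is estimated at 0.015 ug/mL, with a likely range from 0.005 ug/mL to 0.05 ug/mL.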

Compound 4, half-maximal effective concentration: 0.29 ug/mL
Estimate against measurement, compound 4: 19-fold (1.29 log units) below, and the stated range ends below it.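

In this assay, the ethyl extension did not repeat its earlier effect on the core of compound 3: it gave a 10-fold higher number from compound 3 to compound 4 (1.02 log units; beyond the scatter), while the two remaining comparisons gave a 29-fold higher number from compound 2 to compound 4 (1.46 log units; beyond the scatter) and a 2.1-fold lower number from compound 1 to compound 4 (0.32 log units; beyond the scatter). Set side by side, the two ethyl steps run in opposite directions, so a step seen on one core cannot be carried over to the other in this series: the same change on two cores in this assay, a 60-fold lower number (1.78 log units; beyond the scatter) from compound 1 to compound 2 and a 10-fold higher number (1.02 log units; beyond the scatter) from compound 3 to compound 4, 620-fold (2.79 log units) apart, beyond the scatter of two such steps This does not show why they differ, as the ethyl enters on a saturated chain carbon bound to a carbonyl carbon in one case and on a saturated chain carbon four bonds along the chain from an amide-type nitrogen in the other, so the effects of core and place cannot be separated, and two pairs give no general rule.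

The compounds shown leave open how the numbers change from butylamino to hexylamino, for which pentylamino would be the intermediate group, and what a longer chain would give. They also leave open whether a pentyl group on the carbonyl carbon, or a chain ending in an amine or a carboxylic acid, would follow compound 2 or compound 4.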